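A few compounds are considered here, and "the series" means these few. Any claim that something is new, unique, unknown or untested is made for them only; others in the source may bear on it.

Values in an ADME assay on K562 cells (Homo sapiens) for cytotoxicity, with a stated time of 72 h; a lower number here means a stronger inhibitor, a higher number a weaker inhibitor:
Compound 1 `Oc1ccccc1CNc1ncnc2c1ncn2C1CCCCO1`: > 100000 nM, which is a limit of the assay.
Compound 2 `COc1ccccc1CNc1ncnc2c1ncn2C1CCCCO1`: 97000 nM.
Compound 3 `COc1ccc(CNc2ncnc3c2ncn3C2CCCO2)cc1OC`: > 100000 nM, which is a limit of the assay.

Only compound 2 gives a number in this assay; for compound 1 the value is a limit, and for compound 3 as well. The change from compound 2 to compound 1 is hydrogen in place of methyl on an oxygen on an aromatic ring, and it made a step of an at least 1.0-fold higher number from compound 2 to compound 1 (0.01 log units; that floor lies within the scatter), so the two values show no separation in this assay. The difference between the core of compound 3 and the core of compound 2 is not broken down here.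

Compound 4 `COc1cc(CNc2ncnc3c2ncn3C2CCCO2)ccc1O` is not yet measured. It differs from compound 3 by hydrogen in place of methyl on an oxygen on an aromatic ring, the same change as that from compound 2 to compound 1, and both changes sit on an oxygen on an aromatic ring whose other neighbours are aromatic carbon. Beside the earlier step of an at least 1.0-fold higher number from compound 2 to compound 1 (0.01 log units; that floor lies within the scatter), the step from compound 3 to compound 4 is expected to be a step that the limit leaves unreadable from compound 3 to compound 4, resting on that earlier step and on (the limit of > 100000 nM in this assay, at which 2 of the 3 values shown sit). For compound 4 the expected value in this assay is 150000 nM, within 60000 nM to 400000 nM.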

Compound 4, half-maximal inhibitory concentration: > 100000 nM
Compound 4: no number, only a limit (the forecaster's own chance of this, stated with the estimate: 70%); the middle value lies beyond the limit too.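

In this assay, compound 3 and compound 4 both give only a limit of the assay and no number, so no step can be read between them. The compounds shown leave open whether methoxy to hydroxy changes the value on the core of compound 3 at all, a question the limit keeps closed here: the limit of > 100000 nM in this assay, at which 3 of the 4 values shown sit.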